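Furan-2-yl Replaces Chlorophenyl on the Carbonyl Carbon

A few compounds are considered here, and "the series" means these few. Any claim that something is new, unique, unknown or untested is made for them only; others in the source may bear on it.

Three compounds with a shared core have been measured in a functional assay on the whole organism (strain CF-1) with Mus musculus as the target, in the writhing test, with a stated time of 15 min; on this read-out higher numbers stand for an effect only at larger amounts of compound and lower numbers for an effect already at smaller amounts:
- compound 1, `O=C(/N=C1\NC2(CCCCO2)CCS1)Nc1ccccc1`: > 200 mg/kg, a limit of the assay
- compound 2, `O=C(/N=C1\NC2(CCCCO2)CCS1)c1ccc(Cl)cc1`: 1.1 mg/kg
- compound 3, `O=C(/N=C1\NC2(CCCCO2)CCS1)c1ccccc1Cl`: > 200 mg/kg, also a limit of the assay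

Compound 3 therefore stands only at a limit in this assay, not at a number; (the limit of > 200 mg/kg in this assay, at which 2 of the 3 values shown sit). Between compound 1 and compound 3 nothing can be read, since a step that the two limits leave unreadable from compound 1 to compound 3. Two steps are readable: an at least 180-fold lower number from compound 1 to compound 2 (2.25 log units; beyond the scatter), and an at least 180-fold higher number from compound 2 to compound 3 (2.25 log units; beyond the scatter). Both are large, and both change only the group on the carbonyl carbon.

Compound 4, `O=C(/N=C1\NC2(CCCCO2)CCS1)c1ccco1`, is not yet measured. It differs from compound 3 in that (furan-2-yl in place of 2-chlorophenyl on a carbonyl carbon). The two readable steps bear on this place and show that the group there decides whether an effect is seen at all in this assay; neither of them involves furan-2-yl, and compound 3 offers only a limit as starting point. A large step is expected, and the estimate implies an at least 20-fold lower number from compound 3 to compound 4 (1.30 log units; beyond the scatter), though its size rests on a limit. Compound 4 is expected to give about 10 mg/kg, within 1 mg/kg to 200 mg/kg, with a real chance that only a limit is reported.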

Compound 4, dose for half-maximal effect: 42 mg/kg
The estimate for compound 4 lay 4.2-fold (0.62 log units) below the measured number; measured number inside the range.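

Before compound 4, this place on the carbonyl carbon had given one readable number and two limits, so only a sharp contrast could be seen. In this assay furan-2-yl adds a second readable number and a middle position, with an at least 4.7-fold lower number from compound 3 to compound 4 (0.67 log units; beyond the scatter) and with an at least 4.7-fold lower number from compound 1 to compound 4 (0.67 log units; beyond the scatter) as well. It still falls well short of the 4-chlorophenyl group, showing a 38-fold higher number from compound 2 to compound 4 (1.58 log units; beyond the scatter) and so making clear that the outcome at this place among the four compounds is not simply all or nothing, although compound 1 and compound 3 still give no number to set on that scale.

Going by these compounds, how far compound 4 truly lies from compound 1 and compound 3 stays open, as each of those two compounds rests at a limit: the limit of > 200 mg/kg in this assay, at which 2 of the 4 values shown sit. The compounds shown also leave open how other groups on this carbonyl carbon would read in the same test, such as an unsubstituted phenyl, a thiophen-2-yl or a simple methyl, and so whether the furan-2-yl result reflects the ring itself or the absence of chlorine.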